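A few compounds are considered here, and "the series" means these few. Any claim that something is new, unique, unknown or untested is made for them only; others in the source may bear on it.

Three compounds have been examined in a functional assay on the whole organism with Rattus norvegicus as the target; on this read-out lower numbers stand for an effect already at smaller amounts and higher numbers for an effect only at larger amounts of compound. Compound 1 `Nc1ccc2nc(N)sc2c1` reaches only the limit of the measurement, > 10 mg/kg. Compound 2 `Nc1nc2ccc(OCC(F)(F)C(F)(F)F)cc2s1` gives a dose of 7.5 mg/kg. Compound 3 `N=c1sc2cc(OC(F)(F)F)ccc2n1CCS(=O)(=O)O` likewise stops at the limit, > 10 mg/kg. Within the data shown here, compound 3 therefore stands at the limit of > 10 mg/kg in this assay, at which 2 of the 3 values shown sit, and no pair of measured compounds differing in a single place exists here, so no measured step size can be drawn on. Compound 4 `CN(C)CCCn1c(=N)sc2cc(OC(F)(F)F)ccc21` differs from compound 3 by (dimethylamino)methyl in place of sulfo on a saturated chain carbon, two bonds along the chain from an aromatic nitrogen. In this assay the step of an at least 2.0-fold lower number from compound 3 to compound 4 (0.30 log units; that floor lies within the scatter) is expected to carry the dose from the limit into the measurable range, toward smaller amounts, by more than the usual scatter. Compound 4 is estimated at 5 mg/kg, with a range from 1.5 mg/kg to 15 mg/kg.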

Compound 4, dose for half-maximal effect: 9 mg/kg
Estimate against measurement, compound 4: 1.8-fold (0.26 log units) below; the range from low to high includes it.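

In this assay, (dimethylamino)methyl in place of sulfo on a saturated chain carbon, two bonds along the chain from an aromatic nitrogen, gives an at least 1.1-fold lower number from compound 3 to compound 4 (0.04 log units; that floor lies within the scatter). Among these compounds, the change thus brings the chain-substituted series into the measurable range, which the earlier compounds could not show, but the step's printed floor does not establish a change beyond the scatter. The starting point of this step is only a limit: the limit of > 10 mg/kg in this assay, at which 2 of the 4 values shown sit.

On these data alone, the true size of the step remains open. So does whether a carboxylic acid, a primary amine or a longer chain at this place would shift the dose.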